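Aryl sulfonyl pyroglutamyl hydrazides: methyl to chloro

The source may hold more compounds than are shown below. What is called first, only, known or untested is meant among the compounds shown, and "the series" means these compounds.

Measured so far:
- compound 1, `Cc1ccc(S(=O)(=O)N2C(=O)CCC2C(=O)NN)cc1`: 52.8%
- compound 2, `Cc1ccc(S(=O)(=O)N2C(=O)CCC2C(=O)NNc2ccccc2)cc1`: 64.3%

Both numbers come from a functional assay on the whole organism with Mus musculus as the target, at a dose of 50 mg/kg by the intraperitoneal route; on this read-out lower numbers stand for less inhibition and higher numbers for more inhibition at the one dose given (going by the name of the read-out). For the measured compounds named here, compound 1 is the lower of the two measured compounds; its nearest neighbour is compound 2, and the single measured step, a number 11.5 percentage points higher from compound 1 to compound 2 (beyond the scatter), is beyond the scatter and reflects phenyl in place of hydrogen on an amine nitrogen.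

Compound 3, `NNC(=O)C1CCC(=O)N1S(=O)(=O)c1ccc(Cl)cc1`, has not been measured. The change from compound 1 is chloro in place of methyl on an aromatic carbon, on an aromatic carbon of a six-membered aromatic ring of carbon only. Going by the values given here, no measured step bears on this position: the only step, from compound 1 to compound 2, alters the hydrazide nitrogen, not the aromatic ring, so it gives no guide to what an exchange on the ring does in this assay.

With nothing to go on beyond the value of compound 1 itself, the expected step is a number 0.2 percentage points higher from compound 1 to compound 3 (within the scatter), that is no change beyond the scatter. The estimate for compound 3 in this assay is therefore 53%, with a range from 38% to 68%.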

Compound 3, a percentage reported as inhibition, in the whole organism at one dose (the size of the read-out at that dose, not a potency): 61.1%
Beside the measured number, compound 3's estimate is 8.1 percentage points below it, within the range that was stated.
By their numbers in this assay, from the lowest: compounds 1, 3 and 2 (each within the scatter of the next, the first and the last beyond it).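

In this assay the aromatic position gets its first reading: chloro in place of methyl on an aromatic carbon, para to a large group, gives a number 8.3 percentage points higher from compound 1 to compound 3 (within the scatter) and so cannot be told apart from no change at this one dose. For the compounds shown here, this exchange on the ring therefore differs from the only earlier step, a number 11.5 percentage points higher from compound 1 to compound 2 (beyond the scatter) at the amine nitrogen, which is printed as beyond the scatter, so the position accepts chloro in place of methyl without a clear loss or gain in this read-out. No measurement in hand accounts for either the size or the direction of the chloro step.

Going by these compounds alone, still open is whether a methoxy, a nitro or an amino group on that same aromatic carbon would shift the number beyond the scatter from compound 1, since methyl and chloro are the only two groups seen there so far. Also open, as far as these compounds go, is what chloro on the ring does when the phenyl group sits on the amine nitrogen of the hydrazide, as the two exchanges are seen only separately, each starting from compound 1.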